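Triazole 4-substituent series: step to compound 4

The source may hold more compounds than are shown below. What is called first, only, known or untested is meant among the compounds shown, and "the series" means these compounds.

In a functional assay on U-937 cells (Homo sapiens) for antiproliferative activity, read by MTT assay, with a stated time of 24 h (on this read-out lower numbers stand for stronger inhibition and higher numbers for weaker inhibition), compound 3 `O=C1O/C(=C\Cn2cc(C3=CCCCC3)nn2)C(OCc2ccccc2)=C1OCc1ccccc1` reports only a limit, > 100000 nM. Compound 1 `O=C1O/C(=C\Cn2cc(Cc3ccccc3)nn2)C(OCc2ccccc2)=C1OCc1ccccc1` likewise reports a limit in this assay, > 100000 nM. Compound 2 `Cc1ccc(-c2cn(C/C=C3\OC(=O)C(OCc4ccccc4)=C3OCc3ccccc3)nn2)cc1` also reports a limit, > 100000 nM. All three values sit at the limit of > 100000 nM in this assay, at which 3 of the 3 values shown sit, so the steps a step that the two limits leave unreadable from compound 1 to compound 3, a step that the two limits leave unreadable from compound 2 to compound 3 and a step that the two limits leave unreadable from compound 1 to compound 2 have no readable size. Compound 4 `O=C1O/C(=C\Cn2cc(-c3ccccn3)nn2)C(OCc2ccccc2)=C1OCc1ccccc1` differs from compound 3 in one place: pyridin-2-yl in place of cyclohex-1-en-1-yl on an aromatic carbon. Within the data shown here, no measured step reaches a pyridin-2-yl, and no measured step has a readable size, so no shift beyond the scatter is expected. The expected step is a number no higher from compound 3 to compound 4 (the limit leaves the size open). Compound 4 is therefore estimated at 100000 nM, with a range from 30000 nM to 300000 nM, most likely again reported as a limit.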

Compound 4, half-maximal inhibitory concentration: 70200 nM
Beside the measured number, compound 4's estimate is 1.4-fold (0.15 log units) above it; the range from low to high includes it.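

In this assay, pyridin-2-yl on this aromatic carbon makes compound 4 the only compound shown with a number rather than a limit: the limit of > 100000 nM in this assay, at which 3 of the 4 values shown sit. The steps are an at least 1.4-fold lower number from compound 3 to compound 4 (0.15 log units; that floor lies within the scatter), an at least 1.4-fold lower number from compound 2 to compound 4 (0.15 log units; that floor lies within the scatter) and an at least 1.4-fold lower number from compound 1 to compound 4 (0.15 log units; that floor lies within the scatter), so each shows only a floor, and the steps among compounds 1, 2 and 3 cannot be read. Among the groups shown, only pyridin-2-yl carries a ring nitrogen, but this rests on compound 4 alone.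

Going by these compounds, whether the position of that nitrogen matters remains open. A pyridin-3-yl, a pyridin-4-yl or an aminomethyl group on this carbon would bear on that question.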